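The source may report more compounds than this note shows. Statements on the series, on what has been measured and on what is new or still open speak of the compounds shown alone.

Compound 1 `Cc1cc(NC(=O)Nc2ccccc2OC(F)(F)F)c2ccccc2n1`: > 25000 nM
Compound 2 `Cc1cc(NC(=O)Nc2ccccc2N)c2ccccc2n1`: > 25000 nM
Compound 3 `COc1ccccc1NC(=O)Nc1cc(C)nc2ccccc12`: > 25000 nM

All three values come from an ADME assay on HEK293 cells (Homo sapiens) for cytotoxicity, with a stated time of 72 h (on this read-out higher numbers stand for an effect only at larger amounts of compound and lower numbers for an effect already at smaller amounts), and each is a limit of the assay and not a number. Compound 2 stands at the limit > 25000 nM and gives no exact starting point.

Compound 4 `Cc1cc(NC(=O)Nc2cccnc2)c2ccccc2n1` has not yet been measured. It carries pyridin-3-yl in place of 2-aminophenyl on an amide-type nitrogen. The closest measured changes lie elsewhere, on a group of the aromatic ring: a step that the two limits leave unreadable from compound 1 to compound 2 and a step that the two limits leave unreadable from compound 2 to compound 3 along with a step that the two limits leave unreadable from compound 1 to compound 3 in the same series. None of them has a readable size, and all the values sit at one limit (the limit of > 25000 nM in this assay, at which 3 of the 3 values shown sit). Going by the values given here, no measured compound carries pyridin-3-yl, which makes these steps only a weak guide.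

Nothing measured shows an effect at smaller amounts, so no step beyond the scatter is expected in this assay, and the expected step is a number no higher from compound 2 to compound 4 (the limit leaves the size open) as estimated here. For compound 4 the estimated value is 25000 nM with an expected range from 12000 nM to 50000 nM and a report of only a limit is the likeliest outcome.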

Compound 4, half-maximal effective concentration: > 25000 nM
Compound 4: only a limit was reported (the forecaster's own chance of this, stated with the estimate: 90%); the middle value sits exactly at the limit.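

In this assay compound 2 and compound 4 each give only a limit and not a number, so no size can be read for the step between them, and all the results coincide: the limit of > 25000 nM in this assay, at which 4 of the 4 values shown sit.

The compounds shown leave open whether any group in this series brings an effect at smaller amounts.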